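The source may hold more compounds than are shown below. What is called first, only, known or untested is meant among the compounds shown, and "the series" means these compounds.

Values in a functional assay on MCF7 cells (Homo sapiens) for antiproliferative activity, read by MTT assay, with a stated time of 48 h; on this read-out lower numbers stand for stronger inhibition and higher numbers for weaker inhibition:
- Compound 1 `CC(C)=CCC[C@](C)(/C=C/[C@@H](OC(=O)C=C(C)C)[C@](C)(O)/C=C/C(=O)/C=C/N1CCN(C)CC1)CC=O`: 8840 nM
- Compound 2 `CC(=O)O[C@@H]1/C=C/[C@@](C)(CCC=C(C)C)C/C=C(/CO)C(=O)/C=C/[C@@]1(C)O`: 7890 nM
- Compound 3 `CC(C)=CCC[C@]1(C)/C=C/[C@@H](OC(=O)C(C)C)[C@](C)(O)/C=C/C(=O)/C(CO)=C\C1`: 11700 nM

Compound 3, at 11700 nM, lies within the scatter of both compound 1 and compound 2, so these three values cannot be ranked. Compound 4 `CCCC(=O)O[C@@H]1/C=C/[C@@](C)(CCC=C(C)C)C/C=C(/CO)C(=O)/C=C/[C@@]1(C)O` differs from compound 3 in one place: propyl in place of isopropyl on a carbonyl carbon. It carries propyl in place of isopropyl on a carbonyl carbon. Going by the values given here, the only measured step at this place put isopropyl in place of methyl, and it was small: a 1.5-fold higher number from compound 2 to compound 3 (0.17 log units; within the scatter). No change beyond the scatter is therefore expected in this assay. The expected outcome is a 1.2-fold lower number from compound 3 to compound 4 (0.07 log units; within the scatter), with no meaningful direction. The estimate for compound 4 is 10000 nM, with an expected range from 5500 nM to 18000 nM.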

Compound 4, half-maximal inhibitory concentration: 6040 nM
Beside the measured number, compound 4's estimate is 1.7-fold (0.22 log units) above it; measured number inside the range.
By their numbers in this assay, from the lowest: compounds 4, 2, 1 and 3 (each within the scatter of the next).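

In this assay, propyl in place of isopropyl on a carbonyl carbon gives a 1.9-fold lower number from compound 3 to compound 4 (0.29 log units; within the scatter), and ethyl in place of hydrogen on a saturated chain carbon bound to a carbonyl carbon gives a 1.3-fold lower number from compound 2 to compound 4 (0.12 log units; within the scatter). Methyl, isopropyl and propyl at this place therefore cannot be told apart in this assay, whether the chain is branched or not. Nothing available explains this result. As far as these compounds go, whether a longer chain, a phenyl ring or an amine at this place would move the number beyond the scatter remains open.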